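The source may hold more compounds than are shown below. What is called first, only, known or untested is meant among the compounds shown, and "the series" means these compounds.

Measured compounds:
Compound 1 `N/C(=N\NC(=S)N1CCSCC1)c1ccccn1`: 86%
Compound 2 `Cc1ccnc(/C(N)=N/NC(=S)N2CCCCC2)c1`: 80%

Both compounds were tested in a functional assay on A-375 cells (Homo sapiens) for cytotoxicity, read by MTT assay, with a stated time of 72 h, tested at 30 uM; a higher number here means more inhibition of growth at the concentration tested, a lower number less inhibition of growth. In this assay compound 1 gives 86% and compound 2 gives 80%. Compound 2 therefore stands lowest of the two numbers, but its nearest neighbour, compound 1, lies within the usual scatter of it, so the two readings cannot be told apart.

The next compound, compound 3 `N/C(=N\NC(=S)N1CCCCC1)c1ccccn1`, differs from compound 2 in one place: hydrogen in place of methyl on an aromatic carbon. Going by the values given here, no pair of measured compounds that differ in a single place is available, so there is no measured step to lean on. Among the compounds with values here, with only two values in hand, both high and close to each other, the expectation is that removing the methyl leaves the growth inhibition where it is, with a step from compound 2 to compound 3 of a number 2 percentage points higher from compound 2 to compound 3 (within the scatter) in this assay, that is, none beyond the scatter. Compound 3 is thus estimated to give 82% in this assay, with a range from 66% to 94%.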

Compound 3, percent growth inhibition at one concentration: 87%
Beside the measured number, compound 3's estimate is 5 percentage points below it; low and high end bracket the measured number.
By their numbers in this assay, from the lowest: compounds 2, 1 and 3 (each within the scatter of the next).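

In this assay, putting hydrogen in place of the methyl on the aromatic carbon opposite the ring nitrogen gives a number 7 percentage points higher from compound 2 to compound 3 (within the scatter) and so the two readings cannot be told apart: among the compounds shown, growth inhibition in these cells does not depend on that methyl. Going by these compounds alone, the first measured comparison at the other end of the molecule points the same way, with piperidin-1-yl in place of thiomorpholin-4-yl on the thiocarbonyl carbon giving a number 1 percentage points higher from compound 1 to compound 3 (within the scatter) and again no difference that can be told from repeat scatter, so both single changes are tolerated here. Nothing measured beyond these readings speaks to what lies behind them.

Methyl and hydrogen are the only groups shown on that aromatic carbon, so it remains open what a carboxylic acid or a longer chain there would do to the growth inhibition. Equally open, as far as these compounds go, is whether morpholin-4-yl or an open-chain amine on the thiocarbonyl carbon would keep the reading in the same high range.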